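Aromatic nitrogen substituent change from compound 2 to compound 3

The compounds below may be only part of what the source reports. "The series", "measured", "known", "first", "only" and "open" are said of these compounds alone.

Measured so far in an assay on Prostate gland for inhibition of steroid 5-alpha-reductase (Rattus norvegicus); on this read-out lower numbers stand for stronger inhibition and higher numbers for weaker inhibition:
Compound 1 `CCCn1ccc2cc(/C(C)=C/C(=O)Nc3ccccc3OCCCC(=O)O)ccc21` gives 190 nM.
Compound 2 `C/C(=C\C(=O)Nc1ccccc1OCCCC(=O)O)c1ccc2c(ccn2CC(C)C)c1` gives 160 nM.

Compound 2 stands at the lower end of the two numbers, yet compound 1 sits within the scatter of it: a 1.2-fold lower number from compound 1 to compound 2 (0.07 log units; within the scatter).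

Compound 3 `C/C(=C\C(=O)Nc1ccccc1OCCCC(=O)O)c1ccc2c(ccn2C(C)c2ccccc2)c1` carries 1-phenylethyl in place of isobutyl on an aromatic nitrogen. Going by the values given here, the only step that touches this position, a 1.2-fold lower number from compound 1 to compound 2 (0.07 log units; within the scatter), swaps one chain for another without a ring and stays within the scatter; no measured step introduces an aromatic ring here. A step beyond the scatter in either direction is therefore not expected, but the range is kept wide. Compound 3 is estimated at 150 nM, between 45 nM and 500 nM, meaning an expected 1.1-fold lower number from compound 2 to compound 3 (0.03 log units; within the scatter).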

Compound 3, half-maximal inhibitory concentration: 19 nM
Beside the measured number, compound 3's estimate is 7.9-fold (0.90 log units) above it; measured number outside the range, below it.
By their numbers in this assay, from the lowest: compound 3; then compounds 2 and 1 (each within the scatter of the next).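

On the aromatic nitrogen of the shared core, in this assay 1-phenylethyl gives an 8.4-fold lower number from compound 2 to compound 3 (0.93 log units; beyond the scatter) and a 10-fold lower number from compound 1 to compound 3 (1.00 log units; beyond the scatter) on the same change of group. So this position does respond to substitution, which the swap between open chains did not show. The entering group adds both a six-membered aromatic ring and more heavy atoms, and these two changes cannot be told apart here; no evidence on hand accounts for the result.

Open, going by these compounds, is whether benzyl or cyclohexylmethyl would give a similar number. Also open, on these data alone, is how a fluorine or methoxy group on the phenyl ring would shift it.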